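This account rests on a few compounds, and the source may have more. Where it says the series, first, only, none or still open, it means among the compounds named here.

Compounds measured in an assay on a protein complex for inhibition of ubiquitin carboxyl-terminal hydrolase 1/WD repeat-containing protein 48 (Homo sapiens), read by fluorescence; on this read-out higher numbers stand for weaker inhibition and lower numbers for stronger inhibition:
compound 1, `COc1ccc(CNc2nc(-c3ccccc3C(F)(F)F)nc3ccccc23)cc1`, 6200 nM
compound 2, `Fc1ccc(CNc2nc(-c3ccccc3C(F)(F)F)nc3ccccc23)cc1`, 3400 nM
compound 3, `COc1cnc(-c2ccccc2C(C)C)nc1NCc1ccc(-c2cccnc2)cc1`, 70 nM

Compounds 1 and 2 share a core and differ only by fluoro in place of methoxy on an aromatic carbon. In this assay that change gave a 1.8-fold lower number from compound 1 to compound 2 (0.26 log units; within the scatter), so the two values are not distinguished by it. Compound 3 has a different core; the difference between the two cores is not broken down here. In this assay compound 3 stands at the lowest number of the three, beyond the scatter from both compound 2 and compound 1.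

Compound 4, `CC(C)c1ccccc1-c1ncc(F)c(NCc2ccc(-c3cccnc3)cc2)n1`, is not yet measured. It differs from compound 3 by fluoro in place of methoxy on an aromatic carbon. Among the measured compounds shown here, this is the same kind of change as the one between compound 1 and compound 2, though the surroundings differ: in compound 3 the carbon lies in a six-membered aromatic ring with two nitrogens, ortho to a large group and para to a 2-isopropylphenyl group, whereas in compound 1 it lies in a ring of carbon only, para to a large group. Because the earlier step was a 1.8-fold lower number from compound 1 to compound 2 (0.26 log units; within the scatter), a small step is expected, a 1.4-fold lower number from compound 3 to compound 4 (0.15 log units; within the scatter). Compound 4 is expected to give about 50 nM, between 18 nM and 140 nM.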

Compound 4, half-maximal inhibitory concentration: 110 nM
For compound 4 the middle estimate is 2.2-fold (0.34 log units) below the measured one; measured number inside the range.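

In this assay, fluoro in place of methoxy gave a 1.6-fold higher number from compound 3 to compound 4 (0.20 log units; within the scatter) and so does not separate this pair, just as it did not separate the earlier pair on the other core. Even so, the change cannot be carried from one core to the other as a single fixed step, since the two steps point in opposite directions and the gap between them lies beyond the scatter: the same change on two cores in this assay, a 1.8-fold lower number (0.26 log units; within the scatter) from compound 1 to compound 2 and a 1.6-fold higher number (0.20 log units; within the scatter) from compound 3 to compound 4, 2.9-fold (0.46 log units) apart, beyond the scatter of two such steps. Among the compounds shown here, this rests on only two pairs, each step being small on its own, so it shows that the outcome can depend on the core but does not show which feature of either core is responsible.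

The compounds shown leave open how other groups on this aromatic carbon, such as a nitrile, an amine or a longer alkoxy chain, would read in this assay. They also leave open what the same change would give on a third core.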